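Methylsulfanyl for methoxy on the furan-3-yl compound

The source may hold more compounds than are shown below. What is called first, only, known or untested is meant among the compounds shown, and "the series" means these compounds.

Measured so far in an ADME assay on BJ cells (Homo sapiens), read by MTT assay, with a stated time of 72 h; a higher number here means a weaker inhibitor, a lower number a stronger inhibitor:
compound 1, `COc1ncnc2c1c(-c1cccs1)cn2[C@@H]1O[C@H](CO)[C@@H](O)[C@H]1O`: 62800 nM
compound 2, `COc1ncnc2c1c(-c1cc3ccccc3o1)cn2[C@@H]1O[C@H](CO)[C@@H](O)[C@H]1O`: 22400 nM
compound 3, `COc1ncnc2c1c(-c1ccoc1)cn2[C@@H]1O[C@H](CO)[C@@H](O)[C@H]1O`: 28800 nM

Compound 3 stands second highest of the three numbers in this assay. Its nearest neighbour is compound 2, the gap being a 1.3-fold higher number from compound 2 to compound 3 (0.11 log units; within the scatter), so the two are not separable here. Its furthest neighbour is compound 1, with a 2.2-fold lower number from compound 1 to compound 3 (0.34 log units; beyond the scatter). The other measured step, a 2.8-fold lower number from compound 1 to compound 2 (0.45 log units; beyond the scatter), is of similar size.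

Compound 4, `CSc1ncnc2c1c(-c1ccoc1)cn2[C@@H]1O[C@H](CO)[C@@H](O)[C@H]1O`, is not yet measured. It differs from compound 3 by methylsulfanyl in place of methoxy on an aromatic carbon.

All three measured steps concern the aromatic group on the shared core: thiophen-2-yl against 1-benzofuran-2-yl and furan-3-yl. Within the data shown here, none of them touches the methoxy group, so no measured step bears on the change from compound 3 to compound 4. The series gives no basis for a direction, and the two groups that swap are counted alike in heavy atoms, donors and acceptors.

For compound 4 the expected step from compound 3 is therefore none beyond the scatter, no change at the digits printed from compound 3 to compound 4 (within the scatter). The estimate for compound 4 in this assay is 28800 nM, with a range of 10000 nM to 80000 nM.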

Compound 4, half-maximal inhibitory concentration: 98800 nM
Estimate against measurement, compound 4: 3.4-fold (0.54 log units) below, and the stated range ends below it.
By their numbers in this assay, from the lowest: compounds 2 and 3 (each within the scatter of the next); then compounds 1 and 4 (each within the scatter of the next).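

In this assay, the aromatic carbon next to the ring nitrogen proves sensitive to its substituent: methylsulfanyl in place of methoxy gives a 3.4-fold higher number from compound 3 to compound 4 (0.54 log units; beyond the scatter). Among these compounds, this is the first measured change at this position, and it lies beyond the scatter even though the swap is only sulfur for oxygen, with the two groups counted alike in heavy atoms, donors and acceptors. The step is modest, the same class as the change of aromatic group in a 2.8-fold lower number from compound 1 to compound 2 (0.45 log units; beyond the scatter), so this position matters at least as clearly as the aromatic group does in the compounds shown, and nothing available here offers a measured explanation for the step.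

The compounds shown leave open whether the same swap gives a step of this direction and size with thiophen-2-yl or 1-benzofuran-2-yl on the shared core instead of furan-3-yl. They also leave open how this position responds to groups of another kind, such as an amine or a longer chain like ethylsulfanyl in place of methylsulfanyl.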